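The compounds below may be only part of what the source reports. "The series", "measured", "known", "first", "only" and "open" are said of these compounds alone.

Of the compounds shown here, two have been measured: compound 1 `CCOc1ccc(-c2cc3c(ncn3CCCN(C)C)c(C#N)n2)cc1C(F)(F)F` gives 27 nM in an assay on isolated protein for inhibition of cathepsin S (Homo sapiens), read by fluorescence (on this read-out higher numbers stand for weaker inhibition and lower numbers for stronger inhibition), and compound 2 `CCOc1ccc(-c2cc3c(ncn3C)c(C#N)n2)cc1C(F)(F)F` gives 40 nM in this assay.

Among the compounds with values here, compound 2 sits within the scatter of compound 1: the only measured step, a 1.5-fold higher number from compound 1 to compound 2 (0.17 log units; within the scatter), is too small to read as a change.

Compound 3 `Cn1cnc2c(C#N)nc(-c3ccc(OCc4ccncc4)c(C(F)(F)F)c3)cc21` differs from compound 2 by pyridin-4-yl in place of methyl on a saturated chain carbon bound to an oxygen on an aromatic ring. Within the data shown here, no measured step touches this place; the step of a 1.5-fold higher number from compound 1 to compound 2 (0.17 log units; within the scatter) alters the group on the aromatic nitrogen and says nothing about the ether side. With no guidance, the expected step is no change at the digits printed from compound 2 to compound 3 (within the scatter), none beyond the scatter. Compound 3 is therefore estimated at 40 nM in this assay, with a range from 10 nM to 160 nM.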

Compound 3, half-maximal inhibitory concentration: 10 nM
Beside the measured number, compound 3's estimate is 4.0-fold (0.60 log units) above it; the measured number falls inside the stated range.
By their numbers in this assay, from the lowest: compound 3; then compounds 1 and 2 (each within the scatter of the next).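

In this assay, the ether side proves to be a place where a change registers: going from ethoxy to (pyridin-4-yl)methoxy gives a 4.0-fold lower number from compound 2 to compound 3 (0.60 log units; beyond the scatter) as the first step beyond the scatter among these compounds. A group with a six-membered aromatic ring is therefore tolerated on this saturated chain carbon, and inhibition is stronger with it than with methyl. No available evidence accounts for this gain.

Phenyl or pyridin-3-yl in place of pyridin-4-yl would test whether the ring nitrogen or its location matters. On these data alone, whether the gain persists alongside the dimethylamino chain of compound 1 remains open.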